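Swapping a chlorothiophene for a chlorophenyl on the alkyne

The source may hold more compounds than are shown below. What is called first, only, known or untested is meant among the compounds shown, and "the series" means these compounds.

Measured so far:
Compound 1 `Cc1ncccc1C#Cc1cc(Cl)ccc1OCC(=O)O` gives 143 nM in an assay on CHO cells for displacement of a labelled ligand from prostaglandin D2 receptor 2 (Homo sapiens), read by scintillation counting; a lower number here means a stronger inhibitor, a higher number a weaker inhibitor.
Compound 2 `O=C(O)COc1ccc(Cl)cc1C#Cc1ccccc1C(F)(F)F` gives 24 nM in this assay.
Compound 3 `O=C(O)COc1ccc(Cl)cc1C#Cc1ccc(Cl)s1` gives 183 nM in this assay.

Compound 3 has the highest number of the three. For the measured compounds named here, its nearest neighbour is compound 1, and the only measured single change, a 1.3-fold higher number from compound 1 to compound 3 (0.11 log units; within the scatter), stays within the scatter. Compound 2 stands well apart with a much lower number.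

Compound 4 `O=C(O)COc1ccc(Cl)cc1C#Cc1ccccc1Cl` has not been measured. It differs from compound 3 by 2-chlorophenyl in place of 5-chlorothiophen-2-yl on a triple-bonded carbon. Going by the values given here, no measured step of this kind exists, so the one change already seen, a swap of one ring for another at the same triple-bonded carbon, only shows that such a swap can leave the number unchanged. Compound 2 also carries a six-membered carbon ring bearing a single substituent at the same place and gives a clearly lower number than compound 3, which suggests that a six-membered carbon ring here can go with stronger binding. The expectation for compound 4 is therefore a moderate drop toward compound 2, a 4.1-fold lower number from compound 3 to compound 4 (0.61 log units; beyond the scatter), with real uncertainty. The estimate for compound 4 is 45 nM, expected to fall between 15 nM and 140 nM.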

Compound 4, inhibition constant: 28 nM
Beside the measured number, compound 4's estimate is 1.6-fold (0.21 log units) above it, within the range that was stated.
By their numbers in this assay, from the lowest: compounds 2 and 4 (each within the scatter of the next); then compounds 1 and 3 (each within the scatter of the next).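

In this assay, for the compounds shown here, the ring on the triple-bonded carbon can clearly move the number: a 6.5-fold lower number from compound 3 to compound 4 (0.82 log units; beyond the scatter) lies beyond the scatter, and so does a 5.1-fold lower number from compound 1 to compound 4 (0.71 log units; beyond the scatter), whereas the one ring swap seen earlier, a 1.3-fold higher number from compound 1 to compound 3 (0.11 log units; within the scatter), stayed within it. The chloro and trifluoromethyl groups, by contrast, cannot be told apart in this comparison, since a 1.2-fold higher number from compound 2 to compound 4 (0.07 log units; within the scatter) stays within the scatter, so two different substituents on the six-membered carbon ring go with numbers of the same order. Among these four compounds, the two carrying a six-membered ring of carbon only, compound 2 and compound 4, now form one group, and compound 1 and compound 3, whose rings contain a hetero atom, form the other, with no compound going against this split. Nothing available here explains the split.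

The compounds shown leave open whether the ring needs a substituent at all, as a plain phenyl ring is not among them. They also leave open whether a smaller methyl or a methoxy group in place of the chloro would keep the number of compound 4.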